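Cyclopropyl to Cyclobutyl on the Amine Side Chain

This account rests on a few compounds, and the source may have more. Where it says the series, first, only, none or still open, it means among the compounds named here.

Within the data shown here, compound 1 `CCCN(Cc1c(C(F)(F)F)nc2n1CCCN2c1c(C)cc(C)cc1C)CC1CC1` is the only compound here with a numerical result in an in vitro assay on IMR-32 cells for displacement of a labelled ligand from corticotropin-releasing factor receptor 1 (Homo sapiens) (on this read-out lower numbers stand for stronger inhibition and higher numbers for weaker inhibition), where compound 1 gives 32 nM. Among the measured compounds shown here, the other measured compound, compound 2 `C=CCN(CC=C)C(=O)c1c(CC)nc2n1CCC(=O)N2c1c(C)cc(C)cc1C`, differs from compound 1 in several places at once, so no single structural step connects the two. In this assay compound 2 reaches only a limit of the assay, > 5000 nM. That leaves the limit of > 5000 nM in this assay, at which 1 of the 2 values shown sits, as the one other result shown, and it gives no guide to small changes around compound 1.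

Compound 3 `CCCN(Cc1c(C(F)(F)F)nc2n1CCCN2c1c(C)cc(C)cc1C)CC1CCC1` differs from compound 1 by cyclobutyl in place of cyclopropyl on a saturated chain carbon bound to an amine nitrogen. For the measured compounds named here, no measured pair shows this kind of change, so the expectation rests only on how little the two named groups differ. The step from compound 1 to compound 3 is expected to be a 1.3-fold higher number from compound 1 to compound 3 (0.10 log units; within the scatter), a change not beyond the usual scatter. Compound 3 is therefore expected to give about 40 nM in this assay, within a range from 15 nM to 120 nM.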

Compound 3, inhibition constant: 21 nM
Compound 3: the middle estimate sits 1.9-fold (0.28 log units) above what was measured; the measured number falls inside the stated range.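

In this assay, putting cyclobutyl in place of cyclopropyl on a saturated chain carbon bound to an amine nitrogen gives a 1.5-fold lower number from compound 1 to compound 3 (0.18 log units; within the scatter), a step within the usual scatter, so the two compounds cannot be told apart on this read-out. Among these compounds, this is the first measured pair at this place, and it shows that a four-membered carbon ring can stand there in place of a three-membered one with no change that the assay can resolve. Nothing measured here bears on why the two rings read alike.

Going by these compounds, both rings contain carbon only and are small, so the reading for a larger ring such as cyclohexyl remains open. Also open, on these data alone, is whether a ring containing oxygen, such as tetrahydropyranyl, or a longer chain such as butyl would read the same at this place.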